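The source may report more compounds than this note shows. Statements on the series, on what has been measured and on what is new or still open speak of the compounds shown alone.

Working notes on the series. Among the compounds with values here, compound 2 (`Cn1cc(C(=N)S)c2c(N)ncnc21`) gives 15000 nM in a functional assay on KB cells (Homo sapiens) for cytotoxicity (on this read-out higher numbers stand for weaker inhibition and lower numbers for stronger inhibition), the only actual number so far. Compound 1 (`Cc1ccccc1Cn1cc(C(=N)S)c2c(N)ncnc21`) reads > 17000 nM in this assay, which is a limit and not a number (the limit of > 17000 nM in this assay, at which 1 of the 2 values shown sits). Within the data shown here, the one measured step is an at least 1.1-fold lower number from compound 1 to compound 2 (0.05 log units; that floor lies within the scatter) and it rests on that limit.

Compound 3 (`CCCn1cc(C(=N)S)c2c(N)ncnc21`) differs from compound 2 by ethyl in place of hydrogen on a saturated chain carbon bound to an aromatic nitrogen and so carries ethyl in place of hydrogen on a saturated chain carbon bound to an aromatic nitrogen. Among the measured compounds shown here, the measured step changes the same place, so with an at least 1.1-fold lower number from compound 1 to compound 2 (0.05 log units; that floor lies within the scatter) as the only guide, no step beyond the scatter is expected in this assay for this change. The expected change is no change at the digits printed from compound 2 to compound 3 (within the scatter) on this estimate. For compound 3 the estimated value is 15000 nM with an expected range from 7000 nM to 30000 nM in this assay.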

Compound 3, half-maximal inhibitory concentration: 17000 nM
Compound 3: the middle estimate sits 1.1-fold (0.05 log units) below what was measured; low and high end bracket the measured number.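

Ethyl in place of hydrogen on a saturated chain carbon bound to an aromatic nitrogen, which also reads as methyl to propyl, leaves the number in this assay within the scatter (a 1.1-fold higher number from compound 2 to compound 3 (0.05 log units; within the scatter)). Within the data shown here, this is the first step at this position that rests on two actual numbers, so compound 2 and compound 3 show no separation between these two chains. Compound 1 remains a limit and not a number: the limit of > 17000 nM in this assay, at which 1 of the 3 values shown sits. Ethyl in place of 2-methylphenyl at this place gives a number no higher from compound 1 to compound 3 (the limit leaves the size open).

From the compounds shown here alone, whether a longer chain, or a chain ending in an amine or a carboxylic acid, would move the number beyond the scatter at this place stays open. Also open, going by these compounds, is how far compound 1, with its 2-methylphenyl, actually stands from the other two.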